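The compounds below may be only part of what the source reports. "The series", "measured", "known", "first", "only" and "open" are said of these compounds alone.

Of the compounds shown here, three of a shared thiazolidinedione series have been measured in a functional assay for agonist activity at Free fatty acid receptor 1 (Homo sapiens), read by FLIPR, in the presence of a further agent that is not named here; a lower number here means that less compound is needed, a higher number that more compound is needed for the effect. Compound 1 `Cc1cccc(Oc2ccc(CC3SC(=O)NC3=O)cc2)c1` gives 203 nM. Within the data shown here, compound 2 `Cc1cccnc1Oc1ccc(CC2SC(=O)NC2=O)cc1` gives 1090 nM, and the single recorded step, a 5.4-fold higher number from compound 1 to compound 2 (0.73 log units; beyond the scatter), exchanges 3-methylphenyl for 3-methylpyridin-2-yl on the oxygen. Compound 3 `O=C1NC(=O)C(Cc2ccc(-c3ccccc3)cc2)S1` gives 2220 nM; it stands highest of the three numbers, with compound 2 nearest and compound 1 furthest.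

The next compound, compound 4 `O=C1NC(=O)C(Cc2ccc(Oc3ccccc3)cc2)S1`, has not yet been measured in this assay. It differs from compound 3 in one place: phenoxy in place of phenyl on an aromatic carbon. Among the measured compounds shown here, no measured step exchanges phenyl for phenoxy, so the recorded step from compound 1 to compound 2 bears on it only indirectly, through the observation that both aryloxy compounds show lower numbers than compound 3. Compound 4 carries the aryloxy link of compound 1 but lacks its methyl, so a lower number than compound 3, yet not as low as compound 1, is expected, a step of roughly a 5.6-fold lower number from compound 3 to compound 4 (0.74 log units; beyond the scatter). Compound 4 is therefore estimated at 400 nM, within a range of 130 nM to 1200 nM.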

Compound 4, half-maximal effective concentration: 307 nM
For compound 4 the middle estimate is 1.3-fold (0.11 log units) above the measured one, within the range that was stated.
By their numbers in this assay, from the lowest: compounds 1 and 4 (each within the scatter of the next); then compound 2; then compound 3.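

In this assay, among these compounds, phenoxy in place of phenyl on an aromatic carbon gives a 7.2-fold lower number from compound 3 to compound 4 (0.86 log units; beyond the scatter) and so shows directly that adding the oxygen at this position lowers the number, a reading the earlier compounds offered only across more than one change. The methyl of compound 1 proves dispensable in this assay, since a 1.5-fold higher number from compound 1 to compound 4 (0.18 log units; within the scatter) stays within the scatter. The simple phenyl on the oxygen also compares well with the 3-methylpyridin-2-yl group, with a 3.6-fold lower number from compound 2 to compound 4 (0.55 log units; beyond the scatter) as the step.

Still open, as far as these compounds go, is how an amine or a methylene link in place of the oxygen, a plain pyridin-2-yl group or a carboxylic acid on the phenyl of the phenoxy group would compare with compound 4. Nothing available here explains why these steps take the sizes they do.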